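This account rests on a few compounds, and the source may have more. Where it says the series, first, only, none or still open, it means among the compounds named here.

Compound 1 `CNC(=O)c1cc(Oc2ccc3nc(Nc4ccccc4)ncc3c2)ccn1` was examined in an ADME assay on Caco-2 cells (Homo sapiens) for permeability, in the apical to basolateral direction; on this read-out higher numbers stand for higher permeability and lower numbers for lower permeability. In this assay compound 1 gives < 1 10^-6 cm/s, which is a limit of the assay rather than a number. Compound 2 `CNC(=O)c1cc(Oc2ccc3nc(Nc4ccccc4Oc4ccccc4)ncc3c2)ccn1` gives < 1 10^-6 cm/s, again a limit. Compound 3 `CNC(=O)c1cc(Oc2ccc3nc(Nc4cccc(OC(F)(F)F)c4)ncc3c2)ccn1` gives < 1 10^-6 cm/s, also a limit. Because all three values sit at the limit of < 1 10^-6 cm/s in this assay, at which 3 of the 3 values shown sit, the steps a step that the two limits leave unreadable from compound 1 to compound 2 and a step that the two limits leave unreadable from compound 1 to compound 3 cannot be sized. Compound 4 `CNC(=O)c1cc(Oc2ccc3nc(Nc4ccc(-c5cccnc5)cc4)ncc3c2)ccn1` differs from compound 1 by pyridin-3-yl in place of hydrogen on an aromatic carbon. Both measured steps likewise put a group in place of hydrogen on an aromatic carbon, and neither lifted the value out from under the limit, so no step beyond the scatter is expected in this assay. Compound 4 is therefore expected to give 0.7 10^-6 cm/s, within 0.2 10^-6 cm/s to 2.5 10^-6 cm/s, which would mean a step that the limit leaves unreadable from compound 1 to compound 4.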

Compound 4, apparent permeability: < 1 10^-6 cm/s
Compound 4: only a limit was reported (the forecaster's own chance of this, stated with the estimate: 70%); the middle value lies beyond the limit too.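

The step from compound 1 to compound 4 cannot be read, as both results are limits of the assay, not numbers: the limit of < 1 10^-6 cm/s in this assay, at which 4 of the 4 values shown sit. The compounds shown leave open whether any added group shifts the value in this assay.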